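Swapping furan for thiophene on the amide of compound 3

A few compounds are considered here, and "the series" means these few. Any claim that something is new, unique, unknown or untested is made for them only; others in the source may bear on it.

Among the measured compounds shown here, compound 3, `O=C(/C=C/c1cccc([N+](=O)[O-])c1)c1ccc(NC(=O)c2ccco2)cc1`, gives 4100 nM in a functional assay on HCT-116 cells (Homo sapiens) for cytotoxicity, read by resazurin assay, with a stated time of 48 h (a higher number here means that more compound is needed for the effect, a lower number that less compound is needed), the lowest of the three numbers measured so far. The other two compounds share a thiophene amide: compound 1, `O=C(/C=C/c1ccco1)c1ccc(NC(=O)c2cccs2)cc1`, gives 45000 nM, and compound 2, `O=C(/C=C/c1ccccc1)c1ccc(NC(=O)c2cccs2)cc1`, gives 16000 nM. For the measured compounds named here, the only single-point step among them, a 2.8-fold lower number from compound 1 to compound 2 (0.45 log units; beyond the scatter), concerns the group on the double-bonded chain, not the amide.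

Compound 4, `O=C(/C=C/c1cccc([N+](=O)[O-])c1)c1ccc(NC(=O)c2cccs2)cc1`, differs from compound 3 in one place: thiophen-2-yl in place of furan-2-yl on a carbonyl carbon. Going by the values given here, no measured pair shows this exact exchange, since compound 1 and compound 2 also differ from compound 3 on the chain end, so their values cannot isolate the effect of the amide ring. The change keeps the ring size, the single hetero atom and the acceptor count the same, so there is nothing in the numbers above to point toward a large shift in either direction.

Compound 4 is therefore expected to land close to compound 3, with an expected step of a 1.0-fold lower number from compound 3 to compound 4 (0.01 log units; within the scatter), within the usual scatter. The estimate for compound 4 in this assay is 4000 nM, in a range from 1500 nM to 11000 nM.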

Compound 4, half-maximal effective concentration: 2500 nM
Estimate against measurement, compound 4: 1.6-fold (0.20 log units) above, and the stated range covers the measured number.
By their numbers in this assay, from the lowest: compounds 4 and 3 (each within the scatter of the next); then compound 2; then compound 1.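

In this assay, among the compounds shown here, thiophen-2-yl in place of furan-2-yl on the carbonyl carbon gives the first direct reading of the amide ring (a 1.6-fold lower number from compound 3 to compound 4 (0.21 log units; within the scatter)), and with the 3-nitrophenyl chain end in place, the two rings cannot be told apart. For the compounds shown here, with the thiophene amide held fixed, the chain end gives steps beyond the scatter: nitro in place of hydrogen on an aromatic carbon gives one (a 6.4-fold lower number from compound 2 to compound 4 (0.81 log units; beyond the scatter)), and 3-nitrophenyl in place of furan-2-yl on the double-bonded chain gives another (an 18-fold lower number from compound 1 to compound 4 (1.26 log units; beyond the scatter)), so in these pairs the number answers to a change at the chain end, while the one amide exchange stays within the scatter. Nothing measured here accounts for the size of any of these steps.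

As far as these compounds go, the amide exchange is read with the 3-nitrophenyl chain end only, so whether the two rings also match with a phenyl or furan-2-yl chain end remains open. Also open, from the compounds shown here alone, is how an amine or a carboxylic acid would read in place of the nitro group.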